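Shortening the side chain on a shared core

This account rests on a few compounds, and the source may have more. Where it says the series, first, only, none or still open, it means among the compounds named here.

Of the compounds shown here, three built on one core have been tested in a functional assay on MDA-MB-231 cells (Homo sapiens) for inhibition, read by MTT assay, with a stated time of 72 h; on this read-out higher numbers stand for weaker inhibition and lower numbers for stronger inhibition. Compound 1 `Nc1ncnc2c1c(-c1cnc3[nH]ccc3c1)nn2CCCCCCC(=O)NO` gives 37700 nM. Compound 2 `Nc1ncnc2c1c(-c1cnc3[nH]ccc3c1)nn2CCCCCCCCC(=O)NO` gives 11000 nM, and compound 3 `CNC(=O)CCCCCCCn1nc(-c2cnc3[nH]ccc3c2)c2c(N)ncnc21` gives 15800 nM. Among these three numbers compound 3 stands second highest: to compound 2 the step is a 1.4-fold higher number from compound 2 to compound 3 (0.16 log units; within the scatter), while from compound 1 the step is a 2.4-fold lower number from compound 1 to compound 3 (0.38 log units; beyond the scatter).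

Compound 4 `Nc1ncnc2c1c(-c1cnc3[nH]ccc3c1)nn2CCC(=O)NO` has not been measured. It differs from compound 3 in one place: hydroxycarbamoyl in place of 5-(methylcarbamoyl)pentyl on a saturated chain carbon, two bonds along the chain from an aromatic nitrogen. Among the compounds with values here, two measured steps bear on this change. Lengthening the hydroxamate chain gave a 3.4-fold lower number from compound 1 to compound 2 (0.53 log units; beyond the scatter), so the much shorter chain in compound 4 runs the other way. Swapping the chain end gave a 2.4-fold lower number from compound 1 to compound 3 (0.38 log units; beyond the scatter), a modest step. The shortening dominates, so a clearly higher number is expected. For compound 4 in this assay the estimate is 60000 nM, within a range from 20000 nM to 200000 nM, an expected step of a 3.8-fold higher number from compound 3 to compound 4 (0.58 log units; beyond the scatter).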

Compound 4, half-maximal inhibitory concentration: > 150000 nM
Compound 4: no number, only a limit; the forecaster's own chance of this, stated with the estimate: 25%; middle value at least 2.5-fold (0.39 log units) away from the limit.
By their numbers in this assay, from the lowest: compounds 2 and 3 (each within the scatter of the next); then compound 1. At a limit, above all of these: compound 4.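

In this assay compound 4 gives no number, only a limit: the limit of > 150000 nM in this assay, at which 1 of the 4 values shown sits.

Even so, the steps to it can be read, and all three are beyond the scatter: an at least 3.9-fold higher number from compound 1 to compound 4 (0.59 log units; beyond the scatter), an at least 9.4-fold higher number from compound 3 to compound 4 (0.97 log units; beyond the scatter) and an at least 13-fold higher number from compound 2 to compound 4 (1.13 log units; beyond the scatter). Compound 4, with the shortest chain, therefore shows the weakest inhibition of the four, and keeping hydroxycarbamoyl at the chain end does not preserve activity, as compound 3, with methylcarbamoyl at its chain end, stands well below that limit.

From the compounds shown here alone, how far compound 4 lies past its limit stays open, so the true size of these steps is unknown. Also open, going by these compounds, are whether a chain longer than that of compound 2 lowers the number further and whether a carboxylic acid at the chain end would match hydroxycarbamoyl or methylcarbamoyl.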